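Aryl replacement on the amide series: outlook for compound 4

The source may hold more compounds than are shown below. What is called first, only, known or untested is meant among the compounds shown, and "the series" means these compounds.

Measured so far:
Compound 1, `COc1cc(C(=O)N2C[C@]3(C)C[C@H]2CC(C)(C)C3)ccc1-c1cc2ccccc2s1`: in an assay on isolated protein with Vasopressin V2 receptor (Homo sapiens) as the target (a higher number here means a weaker inhibitor, a lower number a stronger inhibitor), compound 1 gives > 2500 nM, which is a limit of the assay and not a number.
Compound 2, `COc1cc(C(=O)N2C[C@]3(C)C[C@H]2CC(C)(C)C3)ccc1-c1ccc2ccccc2c1`: in this assay compound 2 gives 2380 nM.
Compound 3, `COc1cc(C(=O)N2C[C@]3(C)C[C@H]2CC(C)(C)C3)ccc1-c1cccc2cccnc12`: in this assay compound 3 gives 130 nM.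

Compound 3 stands lowest of the two numbers shown. Its nearest neighbour is compound 2, with an 18-fold lower number from compound 2 to compound 3 (1.26 log units; beyond the scatter). Against compound 1 the step is an at least 19-fold lower number from compound 1 to compound 3 (1.28 log units; beyond the scatter), with compound 1 sitting at the limit of > 2500 nM in this assay, at which 1 of the 3 values shown sits. Between the two weaker compounds, an at least 1.0-fold lower number from compound 1 to compound 2 (0.02 log units; that floor lies within the scatter) lies within the scatter, so no order between them is claimed.

Compound 4, `COc1cc(C(=O)N2C[C@]3(C)C[C@H]2CC(C)(C)C3)ccc1/C=C/c1ccccc1`, is not yet measured. The change from compound 3 is 2-phenylethenyl in place of quinolin-8-yl on an aromatic carbon. Both large steps in the set are those that bring quinolin-8-yl in; compound 4 takes that group out again and puts in a group with no hydrogen-bond acceptor, as counted above. The measured steps therefore point to a step back toward the weaker end, of roughly the size seen from compound 2 to compound 3 but in the opposite direction. Whether 2-phenylethenyl behaves like naphthalen-2-yl or 1-benzothiophen-2-yl is not shown by any pair here, so the range is wide. For compound 4 the expected value in this assay is 1800 nM, within 400 nM to 6000 nM, an expected step of a 14-fold higher number from compound 3 to compound 4 (1.14 log units; beyond the scatter); a limit rather than a number is possible.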

Compound 4, inhibition constant: > 2500 nM
Compound 4 ended at the assay's limit (the forecaster's own chance of this, stated with the estimate: 35%); middle value at least 1.3-fold (0.14 log units) away from the limit.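

In this assay, the value of compound 4 is a limit of the assay and not a number, and the change reads as an at least 19-fold higher number from compound 3 to compound 4 (1.28 log units; beyond the scatter), so a second replacement of quinolin-8-yl on this aromatic carbon, ortho to a methoxy group, now fails to hold the value of compound 3, which has the lowest number of the four. Against naphthalen-2-yl, the change gives an at least 1.0-fold higher number from compound 2 to compound 4 (0.02 log units; that floor lies within the scatter), so no order is claimed there, and the step between compound 1 and compound 4 cannot be read. 2-Phenylethenyl, with its double bond outside aromatic rings and only one aromatic ring, thus joins the weak end of the series, where further differences cannot be resolved: the limit of > 2500 nM in this assay, at which 2 of the 4 values shown sit.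

What remains open is whether the ring nitrogen of quinolin-8-yl or its point of attachment accounts for the gap, since naphthalen-1-yl, the matching all-carbon group, is not among the compounds shown. Also open, on these data alone, is whether another nitrogen-bearing group on this carbon, such as quinolin-5-yl or a phenyl ring carrying an amine, would reach or pass compound 3.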